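The source may hold more compounds than are shown below. What is called first, only, known or untested is meant among the compounds shown, and "the series" means these compounds.

Among the measured compounds shown here, in a functional assay on MOLM-13 cells (Homo sapiens) for antiproliferative activity (on this read-out higher numbers stand for weaker inhibition and lower numbers for stronger inhibition), compound 2 `COC(=O)NC(=O)c1c(C)c(-c2ccc(-c3ccccc3F)cc2)nc2ccc(F)cc12` gives 403 nM, the only true number available so far. Compound 1 `Cc1c(-c2ccc(-c3ccccc3F)cc2)nc2ccc(F)cc2c1C(=O)NC#N` is reported only as a limit, > 3000 nM. Compound 3 `Cc1c(-c2ccc(-c3ccccc3F)cc2)nc2ccc(F)cc2c1C(=O)NS(C)(=O)=O` keeps the shared core and differs from compound 2 by methylsulfonyl in place of methoxycarbonyl on an amide-type nitrogen, with methylsulfonyl in place of methoxycarbonyl on an amide-type nitrogen. For the measured compounds named here, the one measured step at that nitrogen, methoxycarbonyl in place of cyano, is an at least 7.4-fold lower number from compound 1 to compound 2 (0.87 log units; beyond the scatter). Going by the values given here, it shows that the group on this nitrogen can shift the read-out well beyond the scatter, but no measurement yet includes methylsulfonyl, so the size of the next step rests on thin evidence. A modest move towards weaker inhibition is expected, and the estimated change is a 2.0-fold higher number from compound 2 to compound 3 (0.30 log units; within the scatter). For compound 3 the expected value in this assay is 800 nM, with an estimated range of 200 nM to 3000 nM.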

Compound 3, half-maximal inhibitory concentration: 300 nM
For compound 3 the middle estimate is 2.7-fold (0.43 log units) above the measured one; measured number inside the range.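

In this assay, methylsulfonyl in place of methoxycarbonyl on the amide-type nitrogen gives a 1.3-fold lower number from compound 2 to compound 3 (0.13 log units; within the scatter), so this read-out does not separate these two groups at this position. Methylsulfonyl in place of cyano gives an at least 10-fold lower number from compound 1 to compound 3 (1.00 log units; beyond the scatter), which means that the gain over compound 1 now appears with two different groups on this nitrogen rather than with methoxycarbonyl alone. The size of both gains remains a bound, as compound 1 is reported only as a limit: the limit of > 3000 nM in this assay, at which 1 of the 3 values shown sits.

The compounds shown carry only cyano, methoxycarbonyl and methylsulfonyl on this nitrogen. They leave open how an acetyl group, a longer chain such as ethylsulfonyl, or a carboxylic acid in place of the whole substituted amide would read.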